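From an acetylfuran to a formylfuran side chain

The compounds below may be only part of what the source reports. "The series", "measured", "known", "first", "only" and "open" are said of these compounds alone.

Compound 1 `Cc1cc(CCCOc2c(C)cc(-c3nnn(C)n3)cc2C)on1` gives 3.2
Compound 2 `CC(=O)c1ccc(CCCCCOc2c(C)cc(-c3nnn(C)n3)cc2C)o1` gives 3.7
Compound 3 `CC(=O)c1ccc(CCCOc2c(C)cc(-c3nnn(C)n3)cc2C)o1` gives 3.2

In a physicochemical assay for lipophilicity, read by HPLC (on this read-out lower numbers stand for lower lipophilicity and higher numbers for higher lipophilicity), compound 3 stands at 3.2 and is level with compound 1, the pair together lying under compound 2 at 3.7 as the lowest of the three numbers. Compound 4 `Cc1cc(-c2nnn(C)n2)cc(C)c1OCCCCCc1ccc(C=O)o1` carries 2-(5-formylfuran-2-yl)ethyl in place of 5-acetylfuran-2-yl (2-(5-formylfuran-2-yl)ethyl in place of 5-acetylfuran-2-yl on a saturated chain carbon, three bonds along the chain from an oxygen on an aromatic ring) on a saturated chain carbon, three bonds along the chain from an oxygen on an aromatic ring. Within the data shown here, the one measured step at this place is no change at the digits printed from compound 1 to compound 3 (within the scatter) and it offers little guide to a change of this kind. Compound 2 at 3.7 marks the upper reach of the series, and a rise toward it, stopping somewhat short, is expected. The expected step is a number 0.30 log units higher from compound 3 to compound 4 (within the scatter) in this assay on this reasoning. For compound 4 the estimate is 3.5 with an expected range from 3.2 to 3.8.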

Compound 4, partition coefficient: 3.5
For compound 4 middle estimate and measured number coincide at the digits printed; the measured number falls inside the stated range.
By their numbers in this assay, from the lowest: compounds 1, 3, 4 and 2 (each within the scatter of the next, the first and the last beyond it).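

In this assay the saturated chain carbon gives a number 0.30 log units higher from compound 3 to compound 4 (within the scatter) with 2-(5-formylfuran-2-yl)ethyl in place of 5-acetylfuran-2-yl, and a number 0.30 log units higher from compound 1 to compound 4 (within the scatter) with the same group in place of 3-methyl-1,2-oxazol-5-yl. Hydrogen in place of methyl on a carbonyl carbon, the first step read at that place, gives a number 0.20 log units lower from compound 2 to compound 4 (within the scatter) as the result. Nothing at hand explains these steps.

Still open, going by these compounds, is what an amine or a carboxylic acid would give on that chain carbon. A longer chain may or may not carry the number beyond the scatter.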